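A few compounds are considered here, and "the series" means these few. Any claim that something is new, unique, unknown or untested is made for them only; others in the source may bear on it.

Compound 3 (`FC(F)(F)c1ccc(CSc2nc(Nc3cccc(Br)c3)c3ccccc3n2)cc1`) holds the lowest of the two numbers shown in a functional assay on MGC-803 cells (Homo sapiens) for cytotoxicity, read by MTT assay, with a stated time of 72 h (on this read-out lower numbers stand for stronger inhibition and higher numbers for weaker inhibition), where compound 3 gives 23700 nM. Compound 2 (`Cc1ccccc1Nc1nc(SCc2ccc(C(F)(F)F)cc2)nc2ccccc12`) gives 24400 nM, and the step of a 1.0-fold lower number from compound 2 to compound 3 (0.01 log units; within the scatter) lies within the scatter. Compound 1 (`COc1ccccc1Nc1nc(SCc2ccc(C(F)(F)F)cc2)nc2ccccc12`) reaches only a limit of the assay, (the limit of > 50000 nM in this assay, at which 1 of the 3 values shown sits), reported as > 50000 nM. Within the data shown here, the step of an at least 2.1-fold lower number from compound 1 to compound 3 (0.32 log units; beyond the scatter) is the one change of the ring on the nitrogen that moved the number beyond the scatter. Compound 4 (`O=[N+]([O-])c1cccc(Nc2nc(SCc3ccc(C(F)(F)F)cc3)nc3ccccc23)c1`) differs from compound 3 by nitro in place of bromo on an aromatic carbon. Among the measured compounds shown here, no measured step swaps bromo for nitro at this place. Because the step of a 1.0-fold lower number from compound 2 to compound 3 (0.01 log units; within the scatter) stayed within the scatter, the step of a 1.1-fold higher number from compound 3 to compound 4 (0.02 log units; within the scatter) is expected to stay within the scatter too. Compound 4 is therefore estimated at 25000 nM, with a range from 8000 nM to 80000 nM.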

Compound 4, half-maximal inhibitory concentration: > 50000 nM
Compound 4 gave a limit, no number; the forecaster's own chance of this, stated with the estimate: 30%; middle value at least 2.0-fold (0.30 log units) away from the limit.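

In this assay, the swap at this place on the ring gives an at least 2.1-fold higher number from compound 3 to compound 4 (0.32 log units; beyond the scatter), and the change of the whole ring gives an at least 2.0-fold higher number from compound 2 to compound 4 (0.31 log units; beyond the scatter). Compound 2 and compound 3 had stayed within the scatter of each other despite different rings on the nitrogen, whereas compound 4 shows that replacing one group at a single place can matter. Two values are now limits, and the step between compound 1 and compound 4 cannot be read: the limit of > 50000 nM in this assay, at which 2 of the 4 values shown sit.

As far as these compounds go, what an amine or a carboxylic acid would give at this same place remains open.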